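Aminomethyl ring exchange from compound 2 to compound 3

A few compounds are considered here, and "the series" means these few. Any claim that something is new, unique, unknown or untested is made for them only; others in the source may bear on it.

Going by the values given here, in a functional assay on PBMC cells (Homo sapiens) for inhibition, with a stated time of 24 h (on this read-out lower numbers stand for stronger inhibition and higher numbers for weaker inhibition), compound 2 `NCC1(c2cccc(-c3ccnc4[nH]nc(C(F)(F)F)c34)c2)CCC1` gives 90 nM and stands lowest of the two numbers so far, with compound 1 `NCC1(c2cccc(-c3ccnc4[nH]ncc34)c2)CCOCC1` at 550 nM by a gap beyond the scatter. Compound 3 `NCC1(c2cccc(-c3ccnc4[nH]nc(C(F)(F)F)c34)c2)CCOCC1` has 4-(aminomethyl)oxan-4-yl in place of 1-(aminomethyl)cyclobutyl on an aromatic carbon, meta to a large group (4-(aminomethyl)oxan-4-yl in place of 1-(aminomethyl)cyclobutyl on an aromatic carbon). Compound 1 also holds 4-(aminomethyl)oxan-4-yl and reads 550 nM but differs from compound 2 in more than one place, so only a moderate weakening is expected in this assay and it may barely clear the scatter. The estimate is a step of a 1.9-fold higher number from compound 2 to compound 3 (0.28 log units; within the scatter) toward weaker inhibition. Compound 3 is estimated at 170 nM (range 60 nM to 480 nM).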

Compound 3, half-maximal inhibitory concentration: 130 nM
Compound 3: middle estimate off by 1.3-fold (0.12 log units), on the high side; measured number inside the range.
By their numbers in this assay, from the lowest: compounds 2 and 3 (each within the scatter of the next); then compound 1.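

In this assay, 4-(aminomethyl)oxan-4-yl in place of 1-(aminomethyl)cyclobutyl gives a 1.4-fold higher number from compound 2 to compound 3 (0.16 log units; within the scatter) and so does not separate the two rings when trifluoromethyl is present on the core. Going by these compounds alone, with 4-(aminomethyl)oxan-4-yl held fixed, trifluoromethyl in place of hydrogen gives a 4.2-fold lower number from compound 1 to compound 3 (0.63 log units; beyond the scatter) and is the only single change here that moves the number beyond the scatter. No measurement offers a reason for either step.

Open, from the compounds shown here alone, is whether 4-(aminomethyl)piperidin-4-yl would read like these two rings, and whether a methyl group or a nitrile could stand in for trifluoromethyl.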